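Fluoro for Methyl on a Cytotoxicity Read-out

The compounds below may be only part of what the source reports. "The series", "measured", "known", "first", "only" and "open" are said of these compounds alone.

Compound 1 `Cc1ccc(C(=O)N2CCN(CC(=O)N3CCN(CCCc4c[nH]c5ccccc45)CC3)CC2)cc1` and compound 2 `O=C(CN1CCN(C(=O)c2ccc(F)cc2)CC1)N1CCN(CCCc2c[nH]c3ccccc23)CC1` share a core and differ by fluoro in place of methyl on an aromatic carbon. In an ADME assay on SH-SY5Y cells (Homo sapiens) for cytotoxicity, read by MTT assay, with a stated time of 72 h (on this read-out higher numbers stand for weaker inhibition and lower numbers for stronger inhibition), compound 1 gives > 200000 nM, which is a limit of the assay and not a number. In this assay compound 2 gives 188000 nM. The step reads an at least 1.0-fold lower number from compound 1 to compound 2 (0.02 log units; that floor lies within the scatter); because of the limit of > 200000 nM in this assay, at which 1 of the 3 values shown sits, the true size of that step is known only as a minimum. Compound 3 `Cc1ccc(C(=O)N2CCN(CC(=O)N3CCN(CCCc4c[nH]c5ccc(F)cc45)CC3)CC2)cc1` differs from compound 1 by fluoro in place of hydrogen on an aromatic carbon. In this assay compound 3 gives 119000 nM, which makes an at least 1.6-fold lower number from compound 1 to compound 3 (0.22 log units; that floor lies within the scatter). Compound 4 `O=C(CN1CCN(C(=O)c2ccc(F)cc2)CC1)N1CCN(CCCc2c[nH]c3ccc(F)cc23)CC1` has not yet been measured; it differs from compound 3 by fluoro in place of methyl on an aromatic carbon, the same change made from compound 1 to compound 2, at the same place. Resting on an at least 1.0-fold lower number from compound 1 to compound 2 (0.02 log units; that floor lies within the scatter), the step from compound 3 to compound 4 is expected to be a 1.2-fold lower number from compound 3 to compound 4 (0.08 log units; within the scatter). Compound 4 is therefore estimated at 100000 nM, with a likely range from 50000 nM to 200000 nM.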

Compound 4, half-maximal inhibitory concentration: 121000 nM
Compound 4: the middle estimate sits 1.2-fold (0.08 log units) below what was measured, and the stated range covers the measured number.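

In this assay, the new steps are a 1.0-fold higher number from compound 3 to compound 4 (0.01 log units; within the scatter) for fluoro in place of methyl and a 1.6-fold lower number from compound 2 to compound 4 (0.19 log units; within the scatter) for fluoro in place of hydrogen; both lie within the scatter, so neither shows an effect of its change on these cores. Set beside the earlier step, fluoro in place of methyl shows no gap that can be read, and it does not show that the two steps are equal: the same change on two cores in this assay, an at least 1.0-fold lower number (0.02 log units; that floor lies within the scatter) from compound 1 to compound 2 and a 1.0-fold higher number (0.01 log units; within the scatter) from compound 3 to compound 4; the limit leaves it open whether they differ. The same holds for fluoro in place of hydrogen: the same change on two cores in this assay, an at least 1.6-fold lower number (0.22 log units; that floor lies within the scatter) from compound 1 to compound 3 and a 1.6-fold lower number (0.19 log units; within the scatter) from compound 2 to compound 4; the limit leaves it open whether they differ.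

The compounds shown leave open what a chloro, a methoxy or an amine in place of that fluoro would give in this assay. They also leave open whether any such group would produce a step beyond the scatter.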